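Cyclopropyl for 4-chlorophenyl on the ring nitrogen

The compounds below may be only part of what the source reports. "The series", "measured", "known", "first", "only" and "open" are said of these compounds alone.

In a functional assay on HeLa cells (Homo sapiens) for antiproliferative activity, read by MTT assay, with a stated time of 72 h (a lower number here means a stronger inhibitor, a higher number a weaker inhibitor), compound 3 `O=C1COc2ccc(-c3cnc(Cl)c(NS(=O)(=O)c4ccc(F)cc4)c3)cc2N1c1ccc(Cl)cc1` gives > 40000 nM as a limit and not a number. It stands at the limit of > 40000 nM in this assay, at which 1 of the 3 values shown sits, and offers no exact starting point. Compound 4 `O=C1COc2ccc(-c3cnc(Cl)c(NS(=O)(=O)c4ccc(F)cc4)c3)cc2N1C1CC1` differs from it by cyclopropyl in place of 4-chlorophenyl on an amide-type nitrogen in a ring and in nothing else. Compound 1 `COc1ccc(N2C(=O)COc3ccc(-c4cnc(Cl)c(NS(=O)(=O)c5ccc(F)cc5)c4)cc32)cc1` gives 8320 nM in this assay as a measured number. For the measured compounds named here, the one measured step, chloro in place of methoxy on an aromatic carbon, is an at least 4.8-fold higher number from compound 1 to compound 3 (0.68 log units; beyond the scatter) and it bears on the group that leaves. Compound 2 `COc1ncc(-c2ccc3c(c2)N(C2CC2)C(=O)CO3)cc1NS(=O)(=O)c1ccc(F)cc1` carries cyclopropyl on that nitrogen and gives 6030 nM as a measured number, so a lower number is expected for compound 4. The expected size is an at least 6.6-fold lower number from compound 3 to compound 4 (0.82 log units; beyond the scatter) in this assay and lies beyond the scatter. For compound 4 the estimate is 6000 nM with a range from 2000 nM to 20000 nM as expected.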

Compound 4, half-maximal inhibitory concentration: 7180 nM
Estimate against measurement, compound 4: 1.2-fold (0.08 log units) below; the measured number falls inside the stated range.
By their numbers in this assay, from the lowest: compounds 2, 4 and 1 (each within the scatter of the next). At a limit, above all of these: compound 3.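

In this assay, cyclopropyl in place of 4-chlorophenyl on the amide-type nitrogen in a ring gives an at least 5.5-fold lower number from compound 3 to compound 4 (0.74 log units; beyond the scatter), a step read from a limit. Cyclopropyl and 4-methoxyphenyl on that nitrogen are not told apart, a 1.2-fold lower number from compound 1 to compound 4 (0.06 log units; within the scatter), and chloro in place of methoxy is likewise not resolved here, a 1.2-fold higher number from compound 2 to compound 4 (0.08 log units; within the scatter). The same exchange therefore does not carry over between cores: the same change on two cores in this assay, an at least 4.8-fold higher number (0.68 log units; beyond the scatter) from compound 1 to compound 3 and a 1.2-fold higher number (0.08 log units; within the scatter) from compound 2 to compound 4, at least 4.0-fold (0.60 log units) apart, beyond the scatter of two such steps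

From the compounds shown here alone, the true size of the step from compound 3 stays open, since its value is only a limit. Also open, going by these compounds, is how an aminoethyl chain or a carboxylic acid on that nitrogen would read.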